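The source may hold more compounds than are shown below. What is called first, only, known or untested is meant among the compounds shown, and "the series" means these compounds.

Measured so far in a functional assay (aorta) with Rattus norvegicus as the target; a higher number here means that more compound is needed for the effect, a lower number that less compound is needed:
Compound 1 `O=S1(=O)NC(NC2CC2)=Nc2ccc(F)cc21`: > 300 uM (a limit)
Compound 2 `O=S1(=O)NC(NC2CCCC2)=Nc2ccc(F)cc21`: 58 uM

Compound 1 sits at the edge of what this assay can report: its > 300 uM is a limit and not a number. Compound 3 `O=S1(=O)NC(NC2CC2)=Nc2ccc(Br)cc21` keeps the cyclopropyl group on the amine nitrogen and the core of compound 1, and makes a single change: bromo in place of fluoro on an aromatic carbon.

Going by the values given here, no measured step touches that halogen. Among the compounds with values here, the only measured step is an at least 5.1-fold lower number from compound 1 to compound 2 (0.71 log units; beyond the scatter), with cyclopentyl in place of cyclopropyl on an amine nitrogen. It lies beyond the scatter, but at another place, so it bears on the new change only indirectly. It shows that a single change can bring this series off the limit. Within the data shown here, compound 2 at 58 uM gives the only real number to judge by.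

A modest move towards a lower number is therefore expected, though compound 3 may also stay at the limit. The expected size is an at least 3.7-fold lower number from compound 1 to compound 3 (0.57 log units; beyond the scatter). For compound 3 the estimated value is 80 uM, with an expected range from 20 uM to 300 uM.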

Compound 3, concentration for half-maximal effect: 89.4 uM
Beside the measured number, compound 3's estimate is 1.1-fold (0.05 log units) below it; the measured number falls inside the stated range.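

Bromo in place of fluoro on an aromatic carbon gives an at least 3.3-fold lower number from compound 1 to compound 3 (0.52 log units; beyond the scatter) in this assay, with the cyclopropyl group on the amine nitrogen and the rest of the core left unchanged. Going by these compounds alone, this shows that the halogen position can by itself bring this series off the limit, so a change at the amine nitrogen is not the only single change that does so. The size of this step is only a minimum, as compound 1 gives > 300 uM, which is a limit and not a number: the limit of > 300 uM in this assay, at which 1 of the 3 values shown sits.

With only fluoro and bromo shown at this position, it remains open how chloro, iodo, methoxy or trifluoromethyl would read there, and so whether the step belongs to bromo in particular or extends to other groups. On these data alone, it is also open whether bromo at this position and cyclopentyl on the amine nitrogen would combine on the shared core, or whether the effect of one depends on the other.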